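Replacing methyl with dimethylamino on compound 2

A few compounds are considered here, and "the series" means these few. Any claim that something is new, unique, unknown or untested is made for them only; others in the source may bear on it.

In an ADME assay on HepG2 cells (Homo sapiens) for cytotoxicity, with a stated time of 72 h (on this read-out lower numbers stand for an effect already at smaller amounts and higher numbers for an effect only at larger amounts of compound), compound 1 `CSc1ccc(NC(=O)Nc2cc(C)nc3ccccc23)cc1` gives 16000 nM. Compound 2 `Cc1ccc(NC(=O)Nc2cc(C)nc3ccccc23)cc1` reaches only a limit in this assay, > 25000 nM. Compound 3 `Cc1cc(NC(=O)Nc2ccc(N(C)C)cc2)c2ccccc2n1` has dimethylamino in place of methyl on an aromatic carbon, (dimethylamino in place of methyl on an aromatic carbon). For the measured compounds named here, the one measured step at this carbon is methyl in place of methylsulfanyl, an at least 1.5-fold higher number from compound 1 to compound 2 (0.19 log units; that floor lies within the scatter). That small step gives little reason to expect a large one here, so nothing beyond the scatter is anticipated in this assay. The expected step is an at least 1.3-fold lower number from compound 2 to compound 3 (0.14 log units; that floor lies within the scatter). For compound 3 the estimate is 18000 nM, with an expected range of 7000 nM to 40000 nM.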

Compound 3, half-maximal effective concentration: > 25000 nM
Compound 3: no number, only a limit; the forecaster's own chance of this, stated with the estimate: 45%; at least 1.3-fold (0.14 log units) between middle value and limit.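

In this assay, putting dimethylamino in place of methylsulfanyl on this aromatic carbon gives an at least 1.5-fold higher number from compound 1 to compound 3 (0.19 log units; that floor lies within the scatter). Compound 3 reaches only a limit, > 25000 nM, so a group carrying nitrogen at this carbon also gives no measured number. The step between compound 2 and compound 3 cannot be read because both compounds stop at the same limit: the limit of > 25000 nM in this assay, at which 2 of the 3 values shown sit.

Going by these compounds, the true values of compound 2 and compound 3 remain open, so methyl and dimethylamino cannot be ranked here. Also open, on these data alone, is whether a carboxylic acid or a longer chain at this carbon would give a measured number.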